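From compound 3 to compound 4: hydroxy for methoxycarbonyl

This account rests on a few compounds, and the source may have more. Where it says the series, first, only, none or still open, it means among the compounds named here.

In an ADME assay on HEK293 cells (Homo sapiens) for cytotoxicity, read by MTT assay, with a stated time of 72 h (on this read-out higher numbers stand for weaker inhibition and lower numbers for stronger inhibition), compound 1 (`COc1ccc(C2=C(c3cc(OC)c(OC)c(OC)c3)C(=O)C(O)C2)cc1`) gives 6.3 ug/mL. Compound 2 (`COc1cc(C2=C(c3cc(C)c(OC)c(C)c3)C(OC(C)=O)CC2=O)cc(OC)c1OC`) reads > 100 ug/mL, which is a limit and not a number. Compound 3 (`COC(=O)c1cc(C2=C(c3cc(OC)c(OC)c(OC)c3)C(=O)CC2O[SiH2]C(C)(C)C)ccc1OC`) reads > 100 ug/mL, also a limit. Compound 3 therefore stands at the limit of > 100 ug/mL in this assay, at which 2 of the 3 values shown sit.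

Compound 4 (`COc1ccc(C2=C(c3cc(OC)c(OC)c(OC)c3)C(=O)CC2O[SiH2]C(C)(C)C)cc1O`) carries hydroxy in place of methoxycarbonyl on an aromatic carbon, ortho to a methoxy group: hydroxy in place of methoxycarbonyl on an aromatic carbon. Among the measured compounds shown here, no measured pair isolates this change. A large move toward stronger inhibition in this assay is expected, since 6.3 ug/mL is the reading of compound 1, which has no methoxycarbonyl. The estimated change is an at least 8.3-fold lower number from compound 3 to compound 4 (0.92 log units; beyond the scatter). For compound 4 the estimate is 12 ug/mL, with an expected range of 1.5 ug/mL to 100 ug/mL.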

Compound 4, half-maximal inhibitory concentration: 42 ug/mL
Beside the measured number, compound 4's estimate is 3.5-fold (0.54 log units) below it; the range from low to high includes it.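

In this assay, hydroxy in place of methoxycarbonyl on this aromatic carbon, ortho to a methoxy group, gives an at least 2.3-fold lower number from compound 3 to compound 4 (0.37 log units; beyond the scatter). Among the compounds shown here, this is the first sign that this position alone can shift the reading, which the earlier compounds, differing in more than one place, could not show. The full size of the step stays unknown because compound 3 sits at a limit: the limit of > 100 ug/mL in this assay, at which 2 of the 4 values shown sit.

On these data alone, whether the step comes from gaining hydroxy or from losing methoxycarbonyl remains open. So does how an amine or a carboxylic acid on this carbon would read.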